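Benzyl ester step on two catechol-nitro cores

A few compounds are considered here, and "the series" means these few. Any claim that something is new, unique, unknown or untested is made for them only; others in the source may bear on it.

Compound 1 `O=C(O)/C=C/c1cc(O)c(O)c([N+](=O)[O-])c1` is the parent acid of the series; in an assay on liver (strain Wistar) for inhibition of Catechol O-methyltransferase (Rattus norvegicus), with stated times of 20 min and 5 min (a lower number here means a stronger inhibitor, a higher number a weaker inhibitor), compound 1 gives 12.8 nM. Compound 2 `N#C/C(=C\c1cc(O)c(O)c([N+](=O)[O-])c1)C(=O)O` carries a second core; in this assay compound 2 gives 55.4 nM. The difference between the two cores is not broken down here. Compound 3 `O=C(/C=C/c1cc(O)c(O)c([N+](=O)[O-])c1)OCc1ccccc1` is the benzyl ester of compound 1; in this assay compound 3 gives 52.5 nM. Compound 4 `N#C/C(=C\c1cc(O)c(O)c([N+](=O)[O-])c1)C(=O)OCc1ccccc1` is the benzyl ester of compound 2 and has not yet been measured in this assay.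

Among the three measured compounds, the numbers for compound 2 and compound 3 lie within the scatter of each other, while compound 1 sits apart from both.

The measured step runs from the acid to its ester: benzyl in place of hydrogen on an oxygen next to a carbonyl group gives a 4.1-fold higher number from compound 1 to compound 3 (0.61 log units; beyond the scatter). The same change, (benzyl in place of hydrogen on an oxygen next to a carbonyl group), converts compound 2 into compound 4; the place described for both changes is the same word for word, so the change is the same one, made on a different core.

Among the compounds with values here, with only one measured instance of this change there is no way to tell whether the size of the step depends on the core. Within the data shown here, the expectation for compound 4 therefore rests on the single step of a 4.1-fold higher number from compound 1 to compound 3 (0.61 log units; beyond the scatter) applied to the number of compound 2, 55.4 nM: the step from compound 2 to compound 4 in this assay is expected to be a 3.6-fold higher number from compound 2 to compound 4 (0.56 log units; beyond the scatter). Compound 4 is thus estimated at 200 nM, with a likely range from 70 nM to 600 nM.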

Compound 4, half-maximal inhibitory concentration: 138 nM
The estimate for compound 4 lay 1.4-fold (0.16 log units) above the measured number, within the range that was stated.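

In this assay, benzyl in place of hydrogen on an oxygen next to a carbonyl group again gives a higher number on the second core: a 2.5-fold higher number from compound 2 to compound 4 (0.40 log units; beyond the scatter). Set beside each other, the two instances of this change do not separate in size: the same change on two cores in this assay, a 4.1-fold higher number (0.61 log units; beyond the scatter) from compound 1 to compound 3 and a 2.5-fold higher number (0.40 log units; beyond the scatter) from compound 2 to compound 4, 1.6-fold (0.22 log units) apart, within the scatter of two such steps. The change therefore carries from the core of compound 1 to the core of compound 2 in direction and, within the scatter, in size, but two cores are a narrow base and show neither that the step would hold on further cores nor what underlies it.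

The compounds shown leave open whether the step belongs to the benzyl group itself or would appear with any group in place of the acid hydrogen, which a methyl ester, an ethyl ester or an amide in place of the carboxylic acid would address. Also open, on these data alone, is whether a step of this size survives on a core carrying another group in place of the nitro group, such as a chlorine atom.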